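The compounds below may be only part of what the source reports. "The series", "measured", "known", "first", "only" and "open" are said of these compounds alone.

Measured so far:
Compound 1, `COc1ccc2c(c1)OC(c1cc(OC)c(OC)c(OC)c1)C(C(=O)N(C)OC)=C2`: 11700 nM
Compound 2, `CCCCNC(=O)C1=Cc2ccc(OC)cc2OC1c1cc(OC)c(OC)c(OC)c1`: 25500 nM

Both were tested in a functional assay for inhibition of nuclear factor NF-kappa-B complex (Homo sapiens); a lower number here means a stronger inhibitor, a higher number a weaker inhibitor. Compound 2 gives the higher of the two numbers, so of these two it is the weaker inhibitor. Going by the values given here, the one step between them is a 2.2-fold higher number from compound 1 to compound 2 (0.34 log units; beyond the scatter), a change of the group on the carbonyl carbon attached to the shared core.

The next compound, compound 3 `CCOC(=O)C1=Cc2ccc(OC)cc2OC1c1cc(OC)c(OC)c(OC)c1`, has not yet been measured. It differs from compound 2 in one place: ethoxy in place of butylamino on a carbonyl carbon. Among the compounds with values here, this again alters the group on the carbonyl carbon, as the single measured step did. That step, a 2.2-fold higher number from compound 1 to compound 2 (0.34 log units; beyond the scatter), was modest, which suggests that exchanges at this position move the number only mildly. Within the data shown here, no measured example shows an ester standing in for an amide, so the direction cannot be read from the data. The step is therefore expected to be small, in either direction, estimated as a 1.3-fold lower number from compound 2 to compound 3 (0.11 log units; within the scatter). Compound 3 is thus estimated at 20000 nM in this assay, with a range from 7000 nM to 60000 nM.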

Compound 3, half-maximal inhibitory concentration: 25000 nM
Compound 3: middle estimate off by 1.3-fold (0.10 log units), on the low side, within the range that was stated.
By their numbers in this assay, from the lowest: compound 1; then compounds 3 and 2 (each within the scatter of the next).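

In this assay, ethoxy in place of butylamino on the carbonyl carbon gives a 1.0-fold lower number from compound 2 to compound 3 (0.01 log units; within the scatter), so the two numbers cannot be told apart, even though the change swaps an amide for an ester, removes the hydrogen-bond donor and leaves a smaller group. Ethoxy in place of methoxy(methyl)amino gives a 2.1-fold higher number from compound 1 to compound 3 (0.33 log units; beyond the scatter), a modest step that matches the one already seen with butylamino, so among these three compounds only compound 1, with methoxy(methyl)amino, stands apart, and no compound shown goes against this. Nothing available explains why butylamino and ethoxy give such similar numbers or why methoxy(methyl)amino differs from both.

Going by these compounds, it remains open whether a carboxylic acid, a simple unsubstituted amide or a cyclic amine such as piperidine on this carbonyl carbon would give a number close to these three or move it much further. Also open, on these data alone, is whether a longer ester such as butoxy would match ethoxy, which would show if the chain length matters at all here.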